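This account rests on a few compounds, and the source may have more. Where it says the series, first, only, none or still open, it means among the compounds named here.

Measured compounds:
Compound 1, `COc1cccc(CNc2ncnc3c2ncn3[C@@H]2O[C@H](CO)[C@@H](O)[C@H]2O)c1`: in a functional assay on K562 cells (Homo sapiens) for antiproliferative activity, with a stated time of 72 h (on this read-out higher numbers stand for weaker inhibition and lower numbers for stronger inhibition), compound 1 gives > 166000 nM, which is a limit of the assay and not a number.
Compound 2, `OC[C@H]1O[C@@H](n2cnc3c(NCc4cc(F)cc(F)c4)ncnc32)C(O)C1O`: compound 2 gives > 166000 nM, again only a limit.
Compound 3, `OC[C@H]1O[C@@H](n2cnc3c(NCc4ccc(F)c(F)c4F)ncnc32)[C@H](O)[C@@H]1O`: compound 3 gives > 166000 nM, also a limit.

Compound 1 therefore stands at a limit rather than at a measured number, and all three measured compounds sit at the same limit, so none of them can be placed above or below another. Within the data shown here, the only step between two measured compounds that differ in a single place is a step that the two limits leave unreadable from compound 1 to compound 3; with both ends at a limit, its size cannot be read.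

Compound 4, `OC[C@H]1O[C@@H](n2cnc3c(NCc4ccc(F)cc4Cl)ncnc32)[C@H](O)[C@@H]1O`, differs from compound 1 in one place: 2-chloro-4-fluorophenyl in place of 3-methoxyphenyl on a saturated chain carbon bound to a nitrogen on an aromatic ring. Among the measured compounds shown here, the only measured step that bears on this change is the unreadable one just described, and the one piece of evidence is the limit of > 166000 nM in this assay, at which 3 of the 3 values shown sit. No step size in either direction can be derived from these data; the expectation rests simply on every measured compound sitting at the limit. Compound 4 is therefore expected to give about 250000 nM, in a range from 100000 nM to 1000000 nM, most probably reported once more as a limit. The expected step is a step that the limit leaves unreadable from compound 1 to compound 4, meaning no change that can be told apart from the scatter.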

Compound 4, half-maximal inhibitory concentration: 15600 nM
Beside the measured number, compound 4's estimate is 16-fold (1.20 log units) above it; the measured number lies below the stated range.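

Replacing 3-methoxyphenyl with 2-chloro-4-fluorophenyl on a saturated chain carbon bound to a nitrogen on an aromatic ring gives an at least 10-fold lower number from compound 1 to compound 4 (1.02 log units; beyond the scatter). Replacing 2,3,4-trifluorophenyl with 2-chloro-4-fluorophenyl in the same place gives an at least 10-fold lower number from compound 3 to compound 4 (1.02 log units; beyond the scatter), so with the core of compound 1 kept, the group at this position can decide whether a measurable value appears in this assay. Until now this position had shown no readable difference at all, and compound 4 is still the only compound that has left the limit: the limit of > 166000 nM in this assay, at which 3 of the 4 values shown sit.

These results do not show whether the chlorine accounts for the lower number by itself or only works together with the fluorine, and a 2-chlorobenzyl or a 4-fluorobenzyl group at this position would separate the two. From the compounds shown here alone, it also remains open how far the number can fall with other groups on this ring, such as a bromine, an amine or a carboxylic acid, or with a longer chain in place of the single carbon that links the ring to the nitrogen.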